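A few compounds are considered here, and "the series" means these few. Any claim that something is new, unique, unknown or untested is made for them only; others in the source may bear on it.

Measured compounds:
- compound 1 `O=CCN1N=C(c2ccc3ccccc3c2)CC1c1ccccc1[N+](=O)[O-]`: 3360 nM
- compound 2 `COc1ccc(C2CC(c3ccc4ccccc4c3)=NN2CC=O)cc1O`: 1490 nM
- compound 3 `O=CCN1N=C(c2ccc3ccccc3c2)CC1c1cccc(Br)c1`: 9870 nM

All three were tested in a functional assay on IMR-32 cells (Homo sapiens) for cytotoxicity, read by sulforhodamine B assay, with a stated time of 48 h; on this read-out lower numbers stand for stronger inhibition and higher numbers for weaker inhibition. Compound 3 gives the highest number of the three, as the steps of a 2.9-fold higher number from compound 1 to compound 3 (0.47 log units; beyond the scatter) and a 6.6-fold higher number from compound 2 to compound 3 (0.82 log units; beyond the scatter) show; both lie beyond the usual scatter of this assay.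

Compound 4 `O=CCN1N=C(c2ccc3ccccc3c2)CC1/C=C/c1ccccc1` differs from compound 3 in one place: 2-phenylethenyl in place of 3-bromophenyl on a saturated ring carbon. Every measured step in this set swaps the group on that same saturated ring carbon, and all three steps were of modest size: a 2.3-fold lower number from compound 1 to compound 2 (0.35 log units; beyond the scatter), a 2.9-fold higher number from compound 1 to compound 3 (0.47 log units; beyond the scatter) and a 6.6-fold higher number from compound 2 to compound 3 (0.82 log units; beyond the scatter). For the measured compounds named here, none of the measured compounds carries a 2-phenylethenyl group, so the direction of the new step cannot be read from the data; only its likely size can, and the measured steps suggest a change of modest size in this assay. The expected step is therefore a small one, a 1.6-fold lower number from compound 3 to compound 4 (0.22 log units; within the scatter), with a wide band either way. Compound 4 is estimated at 6000 nM, with a range from 1500 nM to 20000 nM.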

Compound 4, half-maximal inhibitory concentration: 17200 nM
The estimate for compound 4 lay 2.9-fold (0.46 log units) below the measured number, within the range that was stated.
By their numbers in this assay, from the lowest: compound 2; then compound 1; then compounds 3 and 4 (each within the scatter of the next).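

In this assay, for the compounds shown here, moving the aromatic ring onto a 2-phenylethenyl group at this saturated ring carbon gives no step that can be told from the scatter against 3-bromophenyl, a 1.7-fold higher number from compound 3 to compound 4 (0.24 log units; within the scatter). Going by these compounds alone, the same group stands clearly apart from the two other aryl groups, with a 5.1-fold higher number from compound 1 to compound 4 (0.71 log units; beyond the scatter) and a 12-fold higher number from compound 2 to compound 4 (1.06 log units; beyond the scatter), and this last step is the first large one at this position, so the measured spread here is wider than the earlier compounds showed. No measurement shown explains these differences.

From the compounds shown here alone, it remains open whether a 2-phenylethyl group, with a single bond in place of the double bond, would give a similar number to 2-phenylethenyl. Every compound shown also keeps the formylmethyl group, so the effect of a carboxylic acid or an amine there remains unknown.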